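Replacing 6-bromohexyl with acetyl on the shared core

The source may report more compounds than this note shows. Statements on the series, on what has been measured and on what is new or still open speak of the compounds shown alone.

In a functional assay on HL-60 cells (Homo sapiens) for cytotoxicity, read by MTT assay, with a stated time of 24 h (on this read-out lower numbers stand for stronger inhibition and higher numbers for weaker inhibition), compound 1 `OCCCOc1c(Br)cc(Br)cc1Oc1ccc(Br)cc1Br` gives 29.9 ug/mL and compound 2 `BrCCCCCCOc1c(Br)cc(Br)cc1Oc1ccc(Br)cc1Br` gives 37.8 ug/mL as its half-maximal concentration. The two numbers stand level, so compound 2 holds no distinct rank so far. Compound 3 `CC(=O)Oc1c(Br)cc(Br)cc1Oc1ccc(Br)cc1Br` has not yet been measured. Going by the values given here, it carries acetyl in place of 6-bromohexyl on an oxygen on an aromatic ring and no measured compound has acetyl there. Among the compounds with values here, the only measured step that bears on this is a 1.3-fold higher number from compound 1 to compound 2 (0.10 log units; within the scatter) and it stayed within the scatter. That step involved a change on the chain, so it is only a weak guide. No clear shift is expected in this assay and the expected step is a 1.7-fold lower number from compound 2 to compound 3 (0.24 log units; within the scatter) with a slight lean towards lower numbers. For compound 3 the estimated value is 22 ug/mL with an expected range from 9 ug/mL to 50 ug/mL in this read-out.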

Compound 3, half-maximal inhibitory concentration: 29.9 ug/mL
Compound 3: the middle estimate sits 1.4-fold (0.13 log units) below what was measured; the measured number falls inside the stated range.
By their numbers in this assay, from the lowest: compounds 1, 3 and 2 (each within the scatter of the next).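

In this assay acetyl on an oxygen on an aromatic ring stands level with both chains compared with it, 6-bromohexyl (a 1.3-fold lower number from compound 2 to compound 3 (0.10 log units; within the scatter)) and 3-hydroxypropyl (no change at the digits printed from compound 1 to compound 3 (within the scatter)). The earlier pair compared only two chains on this oxygen, whereas acetyl is a much smaller group with a carbonyl, and even this change leaves the number within the scatter, so across these three compounds the read-out does not separate the groups on this oxygen. Nothing shown explains why these groups stand level.

Going by these compounds, whether any group on this oxygen can move the number beyond the scatter remains open, since an amine, a carboxylic acid or a bare hydroxy group in place of the whole substituent could behave differently. How far the shared core itself accounts for the values also remains unknown.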